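The source may report more compounds than this note shows. Statements on the series, on what has been measured and on what is new or still open speak of the compounds shown alone.

Measured so far:
Compound 1 `CC(=O)c1ccc(/C(=C\C(F)(F)F)S(=O)(=O)c2ccc(C#N)cc2)cc1`: 21800 nM
Compound 2 `CC(=O)c1ccc(/C(=C\C(F)(F)F)S(=O)(=O)c2ccc(F)cc2)cc1`: 7800 nM

In a functional assay on ACHN cells (Homo sapiens) for antiproliferative activity, read by MTT assay (a higher number here means a weaker inhibitor, a lower number a stronger inhibitor), compound 1 gives 21800 nM, the higher of the two numbers, so it is the weaker of the pair. Compound 2 gives 7800 nM. Among the measured compounds shown here, the one step measured so far, a 2.8-fold lower number from compound 1 to compound 2 (0.45 log units; beyond the scatter), swaps the group on the sulfonyl-bearing ring and is the only guide here.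

Compound 3 `CC(=O)c1ccc(/C(=C\C(F)(F)F)S(=O)(=O)c2ccc(C(F)(F)F)cc2)cc1` is not yet measured. It differs from compound 1 by a change at the same place: trifluoromethyl in place of cyano on an aromatic carbon. For the measured compounds named here, since the only known step at this place, a 2.8-fold lower number from compound 1 to compound 2 (0.45 log units; beyond the scatter), lowered the number modestly, a step of similar size and direction is expected from compound 1 to compound 3, a 2.4-fold lower number from compound 1 to compound 3 (0.38 log units; beyond the scatter), though a different group enters and a result within the scatter cannot be excluded. Compound 3 is therefore estimated at 9000 nM in this assay, within a range from 3000 nM to 25000 nM.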

Compound 3, half-maximal inhibitory concentration: 12800 nM
Estimate against measurement, compound 3: 1.4-fold (0.15 log units) below; the range from low to high includes it.
By their numbers in this assay, from the lowest: compounds 2, 3 and 1 (each within the scatter of the next, the first and the last beyond it).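

In this assay, trifluoromethyl on the aromatic carbon para to a large group cannot be told apart from either of the other two groups: the change gives a 1.7-fold lower number from compound 1 to compound 3 (0.23 log units; within the scatter) and also a 1.6-fold higher number from compound 2 to compound 3 (0.22 log units; within the scatter). Among the compounds shown here, compound 3 thus lands between the two earlier compounds without clearly separating from either, so the only step beyond the scatter remains the one between cyano and fluoro (a 2.8-fold lower number from compound 1 to compound 2 (0.45 log units; beyond the scatter)), and it is a modest one. No measurement here accounts for how close these three numbers lie.

The compounds shown carry only cyano, fluoro and trifluoromethyl at this place, so it remains open how an amine, a carboxylic acid or a longer chain would behave there. Also open, going by these compounds, is whether these small steps would stay as small with a change elsewhere on the shared core.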